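Working notes: bromo in place of fluoro

A few compounds are considered here, and "the series" means these few. Any claim that something is new, unique, unknown or untested is made for them only; others in the source may bear on it.

Measured in a functional assay on MCF7 cells (Homo sapiens); a higher number here means a weaker inhibitor of growth, a lower number a stronger inhibitor of growth:
- compound 1 `COc1cc2ncnc(Nc3ccc(CS(=O)(=O)/C=C/c4ccc(Cl)cc4Cl)cc3)c2cc1OC`: 11000 nM
- compound 2 `COc1cc2ncnc(Nc3ccc(CS(=O)(=O)/C=C/c4ccc(F)cc4)cc3)c2cc1OC`: > 100000 nM

In this assay compound 2 has no number, only the limit > 100000 nM. Compound 3 `COc1cc2ncnc(Nc3ccc(CS(=O)(=O)/C=C/c4ccc(Br)cc4)cc3)c2cc1OC` carries bromo in place of fluoro on an aromatic carbon, para to a large group (bromo in place of fluoro on an aromatic carbon). Among the compounds with values here, the only measured step that bears on this is an at least 9.0-fold higher number from compound 1 to compound 2 (0.95 log units; beyond the scatter), with 4-fluorophenyl in place of 2,4-dichlorophenyl, and it lies beyond the scatter. On that single step, a lower number is expected, moving toward compound 1 at 11000 nM. The expected step is an at least 3.3-fold lower number from compound 2 to compound 3 (0.52 log units; beyond the scatter). Compound 3 is estimated at 30000 nM, with an expected range of 6000 nM to 100000 nM.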

Compound 3, concentration for 50% growth inhibition: 32000 nM
Estimate against measurement, compound 3: 1.1-fold (0.03 log units) below; low and high end bracket the measured number.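

In this assay, bromo in place of fluoro on this aromatic carbon gives the first change measured at this position alone: an at least 3.1-fold lower number from compound 2 to compound 3 (0.49 log units; beyond the scatter). Compound 2 carries only a limit, so the full size of that step stays unknown: the limit of > 100000 nM in this assay, at which 1 of the 3 values shown sits.

With 4-bromophenyl in place of 2,4-dichlorophenyl, the number is still higher, a 2.9-fold higher number from compound 1 to compound 3 (0.46 log units; beyond the scatter), so this single bromo does not match the 2,4-dichlorophenyl of the series' best measured value. Open, as far as these compounds go, is how chloro, methoxy or an amine on this carbon would compare with bromo.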